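The source may hold more compounds than are shown below. What is called first, only, known or untested is meant among the compounds shown, and "the series" means these compounds.

Measured compounds, cytotoxicity on Vero cells:
- compound 1 `Clc1ccc(Nc2ccnc(NCCNc3ccnc4cc(Cl)ccc34)n2)cc1`: 15800 nM
- compound 2 `Cc1ccc(Nc2ccnc(NCCNc3ccnc4cc(Cl)ccc34)n2)cc1`: 13600 nM
- compound 3 `Clc1ccc2c(NCCCCNc3nccc(Nc4ccccc4)n3)ccnc2c1`: 14300 nM

In an ADME assay on Vero cells (Chlorocebus sabaeus) for cytotoxicity, read by neutral red uptake, with a stated time of 72 h (a higher number here means a weaker inhibitor, a lower number a stronger inhibitor), compound 3 stands second highest of the numbers shown; its nearest neighbour is compound 2 and its furthest is compound 1, both within the scatter, so the series so far is flat.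

Compound 4 `Clc1ccc(Nc2ccnc(NCCCCNc3ccnc4cc(Cl)ccc34)n2)cc1` is not yet measured. It differs from compound 3 by chloro in place of hydrogen on an aromatic carbon. Within the data shown here, the only measured step in the same region of the molecule is a 1.2-fold lower number from compound 1 to compound 2 (0.07 log units; within the scatter), a change at the same aromatic carbon that left this assay unmoved. Compound 4 shares this chloro with compound 1, which carries it on a shorter linker; compound 1 gives 15800 nM, again within the scatter of compound 3. Nothing here points to a shift beyond the scatter, in either direction.

Compound 4 is therefore expected to give about 15000 nM in this assay, between 9000 nM and 25000 nM, that is, a step of a 1.0-fold higher number from compound 3 to compound 4 (0.02 log units; within the scatter) that is expected to stay within the scatter.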

Compound 4, half-maximal inhibitory concentration: 11000 nM
Compound 4: middle estimate off by 1.4-fold (0.13 log units), on the high side; low and high end bracket the measured number.
By their numbers in this assay, from the lowest: compounds 4, 2, 3 and 1 (each within the scatter of the next).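

Among these compounds, compound 4 gives the first reading against hydrogen at this carbon; until now, the only step here was one substituent exchanged for another. In this assay, the change from phenyl to 4-chlorophenyl gives a 1.3-fold lower number from compound 3 to compound 4 (0.11 log units; within the scatter), so adding chloro on this aromatic carbon, para to a large group, stays inside the scatter, as does the exchange of chloro for methyl, a 1.2-fold lower number from compound 1 to compound 2 (0.07 log units; within the scatter). With hydrogen, chloro and methyl all represented at this carbon across the two steps, neither step separates the groups in this assay, and nothing measured explains that flat reading.

On these data alone, whether an amine or a carboxylic acid at this carbon would give a step beyond the scatter remains open. Among the compounds shown here, also open is whether a chain longer than the one in compound 4 would shift the number.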